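A Second Dichloroacetamide Group on Compound 1

A few compounds are considered here, and "the series" means these few. Any claim that something is new, unique, unknown or untested is made for them only; others in the source may bear on it.

- compound 1 `Nc1cccc(-c2cccc(NC(=O)C(Cl)Cl)c2)c1`: 26100 nM
- compound 2 `CSc1ccc(-c2cc(NC(=O)C(Cl)Cl)cc(-c3ccc(SC)cc3)c2)cc1`: > 30000 nM
- compound 3 `Cc1ccc(-c2cccc(NC(=O)C(Cl)Cl)c2)cc1`: > 50000 nM

These three compounds were tested in a functional assay on KB 3-1 cells (Homo sapiens) for cytotoxicity, read by MTT assay, with a stated time of 68 h; a higher number here means a weaker inhibitor, a lower number a stronger inhibitor. Among the compounds with values here, compound 1 is the only one with a true number, at 26100 nM. Compound 2 reached only a limit of the assay, > 30000 nM. Compound 3 likewise reached only a limit, > 50000 nM.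

Compound 4 `O=C(Nc1cccc(-c2cccc(NC(=O)C(Cl)Cl)c2)c1)C(Cl)Cl` has not yet been measured. It differs from compound 1 on a nitrogen on an aromatic ring, where (dichloromethyl)carbonyl stands in place of hydrogen, so that amino becomes ((dichloromethyl)carbonyl)amino ((dichloromethyl)carbonyl in place of hydrogen on a nitrogen on an aromatic ring). Within the data shown here, no measured pair shows what such a change does in this assay. A small move toward a lower number is expected, and it may stay within the scatter. With compound 1 at 26100 nM, a large gain would be a surprise. For compound 4, a limit instead of a number remains possible. The estimated change is a 1.5-fold lower number from compound 1 to compound 4 (0.16 log units; within the scatter). For compound 4 the expected value is 18000 nM, with an estimated range from 6000 nM to 50000 nM.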

Compound 4, half-maximal inhibitory concentration: > 50000 nM
Compound 4: only a limit was reported; the forecaster's own chance of this, stated with the estimate: 30%; middle value at least 2.7-fold (0.44 log units) away from the limit.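

Setting (dichloromethyl)carbonyl in place of hydrogen on a nitrogen on an aromatic ring gives, in this assay, an at least 1.9-fold higher number from compound 1 to compound 4 (0.28 log units; that floor lies within the scatter). This is the first step shown at this position, and it brings no move toward a lower number, so the amino group of compound 1 gains nothing from this change. Compound 4 has only a limit of the assay and not a number, so the full size of the step stays unknown: the limit of > 50000 nM in this assay, at which 2 of the 4 values shown sit.

The compounds shown leave open whether the result follows from the loss of the amino group or from the dichloromethyl part of the new group. An acetyl group on the same nitrogen, which carries the carbonyl without the chlorine atoms, would bear on that question.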